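A few compounds are considered here, and "the series" means these few. Any claim that something is new, unique, unknown or untested is made for them only; others in the source may bear on it.

Measured compounds in a functional assay on CHO cells for antagonist activity at Orexin receptor type 2 (Homo sapiens), read by FLIPR; a higher number here means a weaker inhibitor, a lower number a stronger inhibitor:

compound 1 `COc1cccc(C(=O)N2CCCCC2CCOc2ccc(Cl)c(Cl)c2)c1` — 501 nM
compound 2 `N#Cc1cccc(C(=O)N2CCCCC2CCOc2ccc(Cl)c(Cl)c2)c1` — 631 nM

In this assay compound 2 gives 631 nM. Compound 1 gives 501 nM. The step of a 1.3-fold higher number from compound 1 to compound 2 (0.10 log units; within the scatter) lies within the scatter, so the two compounds cannot be told apart on these numbers, and compound 2 stands nowhere distinct from compound 1.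

Compound 3 `O=C(c1ccc(Cl)c(Cl)c1)N1CCCCC1CCOc1ccc(Cl)c(Cl)c1` is not yet measured. Its change from compound 2 is 3,4-dichlorophenyl in place of 3-cyanophenyl on a carbonyl carbon. Among the compounds with values here, the only measured step touching the same carbonyl carbon is a 1.3-fold higher number from compound 1 to compound 2 (0.10 log units; within the scatter), which stayed within the scatter when one substituent was exchanged for another on that ring. Within the data shown here, no measured compound carries the 3,4-dichlorophenyl at this place, so the exchange has no direct precedent. On these numbers the expected step is a 1.1-fold lower number from compound 2 to compound 3 (0.06 log units; within the scatter), none beyond the scatter. Compound 3 is therefore estimated at 550 nM, with a range from 150 nM to 2000 nM.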

Compound 3, inhibition constant: > 3160 nM
Compound 3: a limit, no number; the forecaster's own chance of this, stated with the estimate: 5%; middle value at least 5.7-fold (0.75 log units) from the limit.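

In this assay compound 3 gives a limit of the assay and not a number: the limit of > 3160 nM in this assay, at which 1 of the 3 values shown sits.

The group on the carbonyl carbon is less freely exchangeable than the earlier pair suggested: a 1.3-fold higher number from compound 1 to compound 2 (0.10 log units; within the scatter) gave no distinction, whereas 3,4-dichlorophenyl gives an at least 5.0-fold higher number from compound 2 to compound 3 (0.69 log units; beyond the scatter) and an at least 6.3-fold higher number from compound 1 to compound 3 (0.79 log units; beyond the scatter). This position therefore does respond to the aromatic group it carries, although the size of the loss is bounded only from one side and rests on this single group.

As far as these compounds go, whether the loss needs both chlorines or follows from one alone stays open. Also open, from the compounds shown here alone, is how an unsubstituted phenyl, or a phenyl bearing an amine or a carboxylic acid, would read on this carbonyl carbon in this assay.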